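A Six-Membered Ring Takes the Place of Dimethylcarbamoyl

The source may hold more compounds than are shown below. What is called first, only, known or untested is meant among the compounds shown, and "the series" means these compounds.

Of the compounds shown here, three sharing one core have been measured in a functional assay (aorta) with Rattus norvegicus as the target; a higher number here means that more compound is needed for the effect, a lower number that less compound is needed. Compound 1 `COc1ccc(-c2nc(/N=C(\N)NC3CCCCC3)sc2-c2ccc(OC)cc2)cc1` gives only a limit of the assay, > 100 uM. Compound 2 `COc1ccc(-c2nc(CNC(=O)c3cccnc3)sc2-c2ccc(OC)cc2)cc1` gives 8.2 uM, and compound 3 `COc1ccc(-c2nc(C(=O)N(C)C)sc2-c2ccc(OC)cc2)cc1` gives 3 uM, the lowest of the two numbers, with compound 2 nearest at a 2.7-fold lower number from compound 2 to compound 3 (0.44 log units; beyond the scatter). Compound 4 `COc1ccc(-c2nc(C3=CCN(C)CC3)sc2-c2ccc(OC)cc2)cc1` is not yet measured; it differs from compound 3 in a group of 7 heavy atoms (6 carbon, 1 nitrogen; one six-membered non-aromatic ring with 1 hetero atom) in place of a group of 5 heavy atoms (3 carbon, 1 nitrogen, 1 oxygen; no ring), on an aromatic carbon.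

Among the compounds with values here, two steps bear on this change. Putting dimethylcarbamoyl in place of a group carrying a six-membered non-aromatic ring of carbon only gave an at least 33-fold lower number from compound 1 to compound 3 (1.52 log units; beyond the scatter), and putting it in place of the pyridine-bearing group gave a 2.7-fold lower number from compound 2 to compound 3 (0.44 log units; beyond the scatter). Both steps run toward dimethylcarbamoyl with lower numbers, so the reverse direction, dimethylcarbamoyl leaving for a six-membered non-aromatic ring, is expected to bring a higher number in this assay, a step of modest to large size, estimated as a 5.0-fold higher number from compound 3 to compound 4 (0.70 log units; beyond the scatter). Compound 4 is therefore expected to give 15 uM, between 4 uM and 60 uM.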

Compound 4, concentration for half-maximal effect: 5.9 uM
The estimate for compound 4 lay 2.5-fold (0.41 log units) above the measured number; the measured number falls inside the stated range.
By their numbers in this assay, from the lowest: compounds 3, 4 and 2 (each within the scatter of the next, the first and the last beyond it). At a limit, above all of these: compound 1.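

In this assay the step at this position reads a 2.0-fold higher number from compound 3 to compound 4 (0.29 log units; within the scatter) and shows that a group with a six-membered non-aromatic ring with 1 hetero atom, carrying no carbonyl, can stand here in place of dimethylcarbamoyl with no difference beyond the scatter. The comparison with the pyridine-bearing group reads a 1.4-fold lower number from compound 2 to compound 4 (0.14 log units; within the scatter) and likewise stays within the scatter, so two quite different groups and dimethylcarbamoyl give numbers of similar size here, although compounds 2 and 3 themselves lie beyond the scatter of each other. Within the data shown here, only one step is large, an at least 16-fold lower number from compound 1 to compound 4 (1.22 log units; beyond the scatter), and it starts from a limit: the limit of > 100 uM in this assay, at which 1 of the 4 values shown sits.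

On these data alone, how a carboxylic acid or a primary amine on this aromatic carbon would read remains open. In compound 4 the ring, its nitrogen and its double bond enter together, and their shares cannot be read apart.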